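Amidine series: phenyl on the fused five-membered ring

A few compounds are considered here, and "the series" means these few. Any claim that something is new, unique, unknown or untested is made for them only; others in the source may bear on it.

Compound 2 `N=C(Nc1ccccc1)c1cc2cn[nH]c2cn1` carries the amidine on the shared core with no substituent on the five-membered ring; in a functional assay on HT-1080 cells (Homo sapiens) for cytotoxicity, read by MTT assay, with a stated time of 72 h (a lower number here means a stronger inhibitor, a higher number a weaker inhibitor), compound 2 is recorded as "not determined" (no result reported), so its place on the numbers cannot be stated. Among the measured compounds shown here, the only measured member is compound 1 `Cn1nc(-c2ccccc2)c2cc(C(=N)Nc3ccccc3)ncc21`, which bears both a phenyl group and a methyl on the ring nitrogen; in this assay compound 1 gives 17400 nM, a weak value. Compound 3 `N=C(Nc1ccccc1)c1cc2c(-c3ccccc3)n[nH]c2cn1` has not been measured. It differs from compound 2 by phenyl in place of hydrogen on an aromatic carbon. For the measured compounds named here, no step between two measured compounds is available for this series, so the size and direction of the change from compound 2 to compound 3 in this assay cannot be read from data; with only one number in hand, no step beyond the scatter is assumed. Compound 3 is expected to give about 15000 nM in this assay, with a range from 4000 nM to 60000 nM, because compound 1 gives 17400 nM and shares the phenyl group with it.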

Compound 3, half-maximal inhibitory concentration: 22000 nM
The estimate for compound 3 lay 1.5-fold (0.17 log units) below the measured number; measured number inside the range.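

In this assay, among the compounds shown here, the step of a 1.3-fold higher number from compound 1 to compound 3 (0.10 log units; within the scatter) gives the only reading at the ring nitrogen, and hydrogen in place of methyl on an aromatic nitrogen stays within the usual scatter. The weak level of compound 1 is therefore not tied to the methyl on the ring nitrogen, as compound 3, which carries hydrogen there and keeps the phenyl, gives (22000 nM) in the same assay. No measurement at hand offers a reason for this result.

For the compounds shown here, compound 2 has no number in this assay and no step to or from it can be read, so the contribution of phenyl in place of hydrogen on an aromatic carbon remains unknown. Also open, as far as these compounds go, is whether an amine or a carboxylic acid in place of the phenyl, or a longer chain than methyl on the ring nitrogen, would move the number beyond the scatter.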